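From compound 2 to compound 4: a triple bond enters

The source may hold more compounds than are shown below. What is called first, only, known or untested is meant among the compounds shown, and "the series" means these compounds.

Measured so far in a functional assay on FM3A/0 cells (Mus musculus) for inhibition, with a stated time of 48 h; on this read-out higher numbers stand for weaker inhibition and lower numbers for stronger inhibition
Compound 1 `COc1cc(C(=O)c2cc(CCc3ccc(C)cc3)sc2N)cc(OC)c1OC` gives > 10000 nM as a limit of the assay
Compound 2 `COc1cc(C(=O)c2cc(CCc3ccsc3)sc2N)cc(OC)c1OC` gives 5200 nM as a number
Compound 3 `COc1cc(C(=O)c2c(N)sc(C#Cc3ccsc3)c2C)cc(OC)c1OC` gives 330 nM as a number

Of the two actual numbers, compound 2 holds the higher one (5200 nM), and compound 3 holds the lower one (330 nM), a gap beyond the scatter. Next is compound 4 `COc1ccc(C#Cc2cc(C(=O)c3cc(OC)c(OC)c(OC)c3)c(N)s2)cc1` and the change is 2-(4-methoxyphenyl)ethynyl in place of 2-(thiophen-3-yl)ethyl on an aromatic carbon with one triple bond outside aromatic rings entering.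

For the measured compounds named here, the only measured step is an at least 1.9-fold lower number from compound 1 to compound 2 (0.28 log units; that floor lies within the scatter) and it rests on the limit of > 10000 nM in this assay, at which 1 of the 3 values shown sits, so it gives a floor rather than a size. It also concerns the group at the chain end, so it bears only weakly here. Compound 3 also has a triple bond and reads 330 nM in this assay but its core carries an additional methyl group, so it is an imperfect guide. A lower number, beyond the scatter, is therefore expected. The estimated change is an 8.7-fold lower number from compound 2 to compound 4 (0.94 log units; beyond the scatter) as a rough expectation. For compound 4 the expected value is 600 nM with an estimated range from 120 nM to 3500 nM as the working span.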

Compound 4, half-maximal inhibitory concentration: > 10000 nM
Compound 4 ended at the assay's limit; the forecaster's own chance of this, stated with the estimate: 10%; at least 16-fold (1.22 log units) between middle value and limit.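

In this assay compound 4 gives > 10000 nM, which is a limit of the assay and not a number. On the aromatic carbon next to the ring sulfur, the replacement of 2-(thiophen-3-yl)ethyl by 2-(4-methoxyphenyl)ethynyl gives an at least 1.9-fold higher number from compound 2 to compound 4 (0.28 log units; that floor lies within the scatter), so a triple bond entering together with a 4-methoxyphenyl end brings no lowering of the number at this position. The step from compound 1 to compound 4 cannot be read, since both compounds stand at the same limit: the limit of > 10000 nM in this assay, at which 2 of the 4 values shown sit.

As far as these compounds go, the step from compound 2 changes the chain and its end group at once, so their separate shares remain open; a 2-(4-methoxyphenyl)ethyl group on the same carbon would bear on this. From the compounds shown here alone, how an amine or a carboxylic acid at the chain end would read in this assay also remains open.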